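Series notes: 1-carboxyethoxy and carboxymethoxy analogues

The compounds below may be only part of what the source reports. "The series", "measured", "known", "first", "only" and "open" are said of these compounds alone.

Measured so far in a functional assay on HL-60 cells (Homo sapiens) for antiproliferative activity, with a stated time of 72 h; a lower number here means a stronger inhibitor of growth, a higher number a weaker inhibitor of growth:
Compound 1 `C=C(CC)C(=O)c1ccc(OCC(=O)O)cc1C` gives > 60000 nM, which is a limit of the assay and not a number.
Compound 2 `C=C(CC)C(=O)c1ccc(OC(C)C(=O)O)cc1C` gives > 60000 nM, likewise a limit of the assay and not a number.
Within the data shown here, compound 3 `C=C(CCC)C(=O)c1ccc(OC(C)C(=O)O)c(C)c1C` gives 11200 nM, the only number in the set.

Compound 1 and compound 2 differ by a single change, (hydrogen in place of methyl on a saturated chain carbon bound to a carbonyl carbon and an oxygen on an aromatic ring). Both values sit at the limit of > 60000 nM in this assay, at which 2 of the 3 values shown sit, so the step that the two limits leave unreadable from compound 2 to compound 1 cannot be read in either direction. The core of compound 3 differs from that of compound 2 in more than one place; that difference is not broken down here.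

Compound 4 `C=C(CCC)C(=O)c1ccc(OCC(=O)O)c(C)c1C` has not yet been measured. Among the measured compounds shown here, it differs from compound 3 by hydrogen in place of methyl on a saturated chain carbon bound to a carbonyl carbon and an oxygen on an aromatic ring, the same change as the one between compound 2 and compound 1, at the same place. For the measured compounds named here, the only measured instance of this change, the step that the two limits leave unreadable from compound 2 to compound 1, gives no size. The expectation for compound 4 therefore rests on compound 3 alone, with 11200 nM as the starting point. For compound 4 a step of about a 1.4-fold higher number from compound 3 to compound 4 (0.15 log units; within the scatter) is expected in this assay, kept small since no measured instance shows otherwise. Compound 4 is therefore estimated at 16000 nM, most likely between 5000 nM and 50000 nM, and a result reported only as a limit remains possible.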

Compound 4, concentration for 50% growth inhibition: 19300 nM
Compound 4: middle estimate off by 1.2-fold (0.08 log units), on the low side; measured number inside the range.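

In this assay, replacing 1-carboxyethoxy with carboxymethoxy gives a 1.7-fold higher number from compound 3 to compound 4 (0.24 log units; within the scatter), so the two groups cannot be told apart on this core. On the core of compound 1 and compound 2 the same change cannot be read, as both values are limits of the assay and not numbers: the limit of > 60000 nM in this assay, at which 2 of the 4 values shown sit.

This leaves one readable instance of the change, which shows neither that its small size carries over to the other core nor that it fails to do so.

The compounds shown all carry a carboxylic acid on 1-carboxyethoxy or carboxymethoxy, so the effect of an ester or an amide in its place, or of a longer chain bearing the acid, remains open. Also open, as far as these compounds go, is whether the change stays this small on any further core that gives numbers rather than limits.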